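From dimethylamino to hydroxy on a shared core

The source may report more compounds than this note shows. Statements on the series, on what has been measured and on what is new or still open speak of the compounds shown alone.

Of the compounds shown here, three with a shared core have been measured so far in an ADME assay for pharmacokinetics, read by LC-MS, in phosphate buffer, with a stated time of 120 min, at pH 7.4, tested at 1 uM, in the presence of a further agent that is not named here (a higher number here means that the compound lasts longer, a lower number that the compound disappears faster), as the common test. Compound 1 (`C=C(C(=O)Nc1ccccc1)C(F)(F)F`) stands at 0.25 h on this read-out. Compound 2 (`C/C=C/C(=O)Nc1ccccc1`) gives > 8.53 h as a limit of the assay. Compound 3 (`C=C(CN(C)C)C(=O)Nc1ccccc1`) gives < 0.0334 h as a limit of the assay too, so its place is known from one side only.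

Compound 4 (`C=C(CO)C(=O)Nc1ccccc1`) has not yet been measured. It carries hydroxy in place of dimethylamino on a saturated chain carbon bound to a double-bonded chain carbon. The same change reads (dimethylamino)methyl to hydroxymethyl. For the measured compounds named here, one measured step bears on it, the one that brought in the group now leaving: an at least 7.4-fold lower number from compound 1 to compound 3 (0.87 log units; beyond the scatter) (beyond the scatter, and a bound rather than an exact size). The change is therefore expected to reverse at least part of that drop, with an estimated rise beyond the scatter (an at least 35-fold higher number from compound 3 to compound 4 (1.55 log units; beyond the scatter)). For compound 4 the estimate is 1.2 h as an expected half-life, with an expected range from 0.25 h to 6 h in this assay when it is measured.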

Compound 4, half-life: > 8.53 h
Compound 4 gave a limit, no number; the forecaster's own chance of this, stated with the estimate: 10%; middle value at least 7.1-fold (0.85 log units) from the limit.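

Measured in this assay the change from dimethylamino to hydroxy on a saturated chain carbon bound to a double-bonded chain carbon gives a large rise (an at least 250-fold higher number from compound 3 to compound 4 (2.40 log units; beyond the scatter)), so the short half-life of compound 3 does not come with every group at this place. Hydroxymethyl also compares well with trifluoromethyl on a double-bonded chain carbon bound to a carbonyl carbon (an at least 34-fold higher number from compound 1 to compound 4 (1.53 log units; beyond the scatter)). Compound 4 gives a limit of the assay and not a number: the limit of > 8.53 h in this assay, at which 2 of the 4 values shown sit.

As far as these compounds go, the step from compound 2 to compound 4 cannot be read, and how far compound 4 lasts beyond its limit stays open. Also open, from the compounds shown here alone, is whether a methoxy group, a primary amine or a carboxylic acid at this place would stay close to hydroxy or to dimethylamino.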